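Phenyl to 3,4-dimethoxyphenyl on the butyl compound

A few compounds are considered here, and "the series" means these few. Any claim that something is new, unique, unknown or untested is made for them only; others in the source may bear on it.

In a functional assay on M21 cells (Homo sapiens) for antiproliferative activity, read by sulforhodamine B assay, with a stated time of 48 h (a lower number here means a stronger inhibitor, a higher number a weaker inhibitor), compound 3 (`CCCCN1CCN(c2ccc(S(=O)(=O)Oc3ccccc3)cc2)C1=O`) reads > 100000 nM as a limit of the assay and not a number. It carries a butyl chain and an unsubstituted phenyl on an oxygen whose other neighbour is the sulfonyl sulfur.

The two other measured compounds carry an ethyl chain and methoxy groups on that aromatic ring, and both give numbers. Compound 1 (`CCN1CCN(c2ccc(S(=O)(=O)Oc3cc(OC)c(OC)c(OC)c3)cc2)C1=O`) gives 870 nM in this assay and compound 2 (`CCN1CCN(c2ccc(S(=O)(=O)Oc3ccc(OC)cc3)cc2)C1=O`) gives 26000 nM there. Chain and ring both differ between these two and compound 3, and no measured pair isolates either change.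

Compound 4 (`CCCCN1CCN(c2ccc(S(=O)(=O)Oc3ccc(OC)c(OC)c3)cc2)C1=O`) keeps the butyl chain of compound 3 and has 3,4-dimethoxyphenyl in place of phenyl on an oxygen. A gain in potency beyond the scatter is expected in this assay for this change (an at least 20-fold lower number from compound 3 to compound 4 (1.30 log units; beyond the scatter)). The expectation rests on the methoxy-bearing compound 2 at 26000 nM and the methoxy-bearing compound 1 at 870 nM, with the butyl chain as the main uncertainty. Compound 4 is expected at 5000 nM with an estimated range (from 1200 nM to 25000 nM).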

Compound 4, half-maximal inhibitory concentration: > 100000 nM
Compound 4 was reported as a limit; the forecaster's own chance of this, stated with the estimate: 5%; middle value at least 20-fold (1.30 log units) from the limit.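

In this assay compound 4 reads > 100000 nM, a limit of the assay and not a number. Compound 3 stands at a limit too, so no step between compound 3 and compound 4 can be read: the limit of > 100000 nM in this assay, at which 2 of the 4 values shown sit.

The compounds shown include no pair differing in the chain alone, which leaves the contribution of butyl against ethyl open.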